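Sulfamoyl on the phenyl of compound 1

A few compounds are considered here, and "the series" means these few. Any claim that something is new, unique, unknown or untested is made for them only; others in the source may bear on it.

Compound 1 `COc1cccc(F)c1-c1cccc2nc(Nc3ccccc3)oc12` stands second highest of the three numbers measured in an assay on isolated protein for inhibition of ribosomal protein S6 kinase alpha-2 (Homo sapiens), with a stated time of 150 min (on this read-out higher numbers stand for weaker inhibition and lower numbers for stronger inhibition), where compound 1 gives 1000 nM. Its nearest neighbour is compound 3 `COc1ccc(Nc2nc3cccc(-c4c(F)cccc4OC)c3o2)cc1`, which in this assay gives 1400 nM; the step of a 1.4-fold higher number from compound 1 to compound 3 (0.15 log units; within the scatter) put methoxy in place of hydrogen on the phenyl on the nitrogen. Compound 2 `COc1cccc(Nc2nc3cccc(-c4c(F)cccc4OC)c3o2)n1` in this assay gives 620 nM; the step of a 1.6-fold lower number from compound 1 to compound 2 (0.21 log units; within the scatter) replaced that phenyl altogether. Compound 4 `COc1cccc(F)c1-c1cccc2nc(Nc3cccc(S(N)(=O)=O)c3)oc12` differs from compound 1 by sulfamoyl in place of hydrogen on an aromatic carbon. For the measured compounds named here, no measured step introduces a sulfamoyl, so none bears directly on this change; the only guide is that both changes to the phenyl of compound 1 stayed within the scatter. The expected step is therefore small, a 1.4-fold lower number from compound 1 to compound 4 (0.15 log units; within the scatter). Compound 4 is estimated at 700 nM, with a range from 250 nM to 2000 nM.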

Compound 4, half-maximal inhibitory concentration: 340 nM
Estimate against measurement, compound 4: 2.1-fold (0.31 log units) above; low and high end bracket the measured number.
By their numbers in this assay, from the lowest: compounds 4, 2, 1 and 3 (each within the scatter of the next, the first and the last beyond it).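

Sulfamoyl gives, in this assay, a 2.9-fold lower number from compound 1 to compound 4 (0.47 log units; beyond the scatter), the first change to this phenyl that lies beyond the scatter, though only modestly; methoxy gave a 1.4-fold higher number from compound 1 to compound 3 (0.15 log units; within the scatter). A substituent meta to a large group on this ring can therefore lower the number, so this ring is not indifferent to every change. No measurement here accounts for the sulfamoyl step.

Going by these compounds, it remains open whether a carboxylic acid, an amine or a methylsulfonyl in the same place would give a similar step. Also open, on these data alone, is whether sulfamoyl would lower the number on the 6-methoxypyridin-2-yl of compound 2.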